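Swapping the Core Substituent in a Cytotoxicity Series

A few compounds are considered here, and "the series" means these few. Any claim that something is new, unique, unknown or untested is made for them only; others in the source may bear on it.

Among the compounds with values here, compound 1 `COc1ccc(F)cc1CNCCCNc1ccnc2cc(Cc3ccc(C#N)cc3)ccc12` is one of two compounds tested so far. In an ADME assay on HepG2 cells (Homo sapiens) for cytotoxicity, read by luminescence, CellTiter-Glo and ATP content, with a stated time of 72 h (a lower number here means that less compound is needed, a higher number that more compound is needed for the effect), compound 1 gives 6050 nM, the lowest of the two numbers, and compound 2 `N#Cc1ccc(Cc2ccc3c(NCCCNCc4ccco4)ccnc3c2)cc1` gives 7910 nM; the step of a 1.3-fold higher number from compound 1 to compound 2 (0.12 log units; within the scatter) changes a group on the chain, not the core. Compound 3 `COc1ccc(F)cc1CNCCCNc1ccnc2cc(Oc3ccccc3)ccc12` differs from compound 1 at the core: phenoxy in place of 4-cyanobenzyl on an aromatic carbon. Within the data shown here, no measured step touches this position, so the expectation for compound 3 rests only on the narrow spread of compounds 1 and 2, and a step of about a 1.2-fold higher number from compound 1 to compound 3 (0.06 log units; within the scatter) is estimated. Compound 3 is expected near 7000 nM, between 2500 nM and 20000 nM.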

Compound 3, half-maximal effective concentration: 1500 nM
For compound 3 the middle estimate is 4.7-fold (0.67 log units) above the measured one; the whole stated range lies above it.
By their numbers in this assay, from the lowest: compound 3; then compounds 1 and 2 (each within the scatter of the next).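

In this assay, the group on the aromatic carbon of the shared core moves the number clearly: phenoxy in place of 4-cyanobenzyl gives a 4.0-fold lower number from compound 1 to compound 3 (0.61 log units; beyond the scatter). Within the data shown here, this is the first step beyond the usual scatter, whereas the one change on the chain stayed within it. No measurement at hand accounts for this shift.

The compounds shown do not separate the effect of the phenoxy oxygen from that of losing the nitrile. An unsubstituted benzyl group or a 4-cyanophenoxy group at this position would tell the two apart.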